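The source may report more compounds than this note shows. Statements on the series, on what has been measured and on what is new or still open speak of the compounds shown alone.

In a functional assay on the whole organism for antagonist activity, with Mus musculus as the target (a lower number here means that less compound is needed, a higher number that more compound is needed for the effect), three compounds have been measured so far:

- compound 1 `CC(=O)N(c1ccccc1)C1CCCC1N(C)C` gives 9 mg/kg
- compound 2 `CCC(=O)N(c1ccc(C(C)=O)cc1)C1CCCC1N(C)C` gives 40 mg/kg
- compound 3 `CCC(=O)N(c1ccc(Cl)c(Cl)c1)C1CCCC1N` gives 0.8 mg/kg

Compound 3 has the lowest number of the three, and the gaps up to compound 1 and compound 2 both lie beyond the usual scatter. The next compound to be tested is compound 4 `CCC(=O)N(c1ccc(Cl)c(Cl)c1)C1CCCC1N(CC)CC` which changes a single group of compound 3: diethylamino in place of amino on a saturated ring carbon. Among the compounds with values here, no measured pair shows this change on its own, so any expectation is rough. Still, the nitrogen carries carbon groups in compound 1 (9 mg/kg) and in compound 2 (40 mg/kg). Both need more compound than compound 3 (0.8 mg/kg), though they also differ from it elsewhere. A rise beyond the scatter in this assay is therefore expected, with an estimated 7.5-fold higher number from compound 3 to compound 4 (0.88 log units; beyond the scatter) as the working figure. Compound 4 is estimated at 6 mg/kg (expected range 1.2 mg/kg to 30 mg/kg).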

Compound 4, dose for half-maximal effect: 0.03 mg/kg
The estimate for compound 4 lay 200-fold (2.30 log units) above the measured number; measured number below the stated range.
By their numbers in this assay, from the lowest: compound 4; then compound 3; then compound 1; then compound 2.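

Within the shared core, putting diethylamino in place of amino on a saturated ring carbon gives, in this assay, a 27-fold lower number from compound 3 to compound 4 (1.43 log units; beyond the scatter), so carbon groups on this nitrogen can go with much less compound being needed. Within the data shown here, this single-change pair is the first direct reading of this position, and it shows that the position accepts a group much larger than amino while the number still falls. Two things change together here, the added carbon and the loss of the hydrogen-bond donor, and no measurement available explains the drop or separates these two changes.

On these data alone, it remains open whether ethylamino, with only one carbon chain on the nitrogen, would already bring much of this drop. As far as these compounds go, it is also open whether a longer chain such as dipropylamino, or a ring amine such as pyrrolidine, would lower the number further or reverse it.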